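The source may report more compounds than this note shows. Statements on the series, on what has been measured and on what is new or still open speak of the compounds shown alone.

Measured in a functional assay on A2780 cells (Homo sapiens) for antiproliferative activity, read by MTT assay, with a stated time of 72 h; on this read-out higher numbers stand for weaker inhibition and lower numbers for stronger inhibition:
- compound 1 `COc1ccc(C2CC(c3ccc(Cl)cc3)=NN2C(=O)c2cc3ccccc3o2)cc1`: 5.74 ug/mL
- compound 2 `O=C(c1cc2ccccc2o1)N1N=C(c2ccc(Cl)cc2)CC1c1ccc([N+](=O)[O-])cc1`: 34.1 ug/mL

Compound 2 stands at 34.1 ug/mL, the higher of the two numbers in this assay, and so shows the weaker inhibition. The next structure, compound 3 `O=C(c1cc2ccccc2o1)N1N=C(c2ccc(F)cc2)CC1c1ccc([N+](=O)[O-])cc1`, differs from compound 2 by fluoro in place of chloro on an aromatic carbon, para to a large group.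

Within the data shown here, only one measured step is available, a 5.9-fold higher number from compound 1 to compound 2 (0.77 log units; beyond the scatter). It is a modest step beyond the scatter, but it is nitro in place of methoxy, a change at another place in the molecule. Among the measured compounds shown here, no measured compound pair covers an exchange of chloro for fluoro, so that step gives neither a size nor a direction for this one. The working expectation in this assay is therefore no step beyond the scatter, with compound 2 at 34.1 ug/mL as the anchor. The expected step is a 1.1-fold lower number from compound 2 to compound 3 (0.06 log units; within the scatter). The estimated value for compound 3 is 30 ug/mL, with an expected range of 13 ug/mL to 65 ug/mL.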

Compound 3, half-maximal inhibitory concentration: > 50 ug/mL
Compound 3 ended at the assay's limit; the forecaster's own chance of this, stated with the estimate: 5%; middle value at least 1.6-fold (0.22 log units) away from the limit.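

Among these compounds, the exchange of 4-chlorophenyl to 4-fluorophenyl gives the first reading at this position, on an aromatic carbon para to a large group, and in this assay it gives an at least 1.4-fold higher number from compound 2 to compound 3 (0.16 log units; that floor lies within the scatter). With the nitro group held in place, fluoro in place of chloro therefore brings no gain in inhibition, although this floor alone does not place the step beyond the scatter and its true size may be larger. The reading for compound 3 is a limit of the assay and not a number: the limit of > 50 ug/mL in this assay, at which 1 of the 3 values shown sits.

Still open are the true value of compound 3 and whether the same exchange of chloro for fluoro gives a step of similar size or direction when the methoxy group of compound 1 replaces the nitro group, since the compounds shown offer only this one pair for the change. Also open is how this assay would read with an amine, a carboxylic acid or a longer chain such as butyl in this position on the aromatic ring, as no such group stands among the compounds shown.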